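The source may hold more compounds than are shown below. What is called first, only, known or untested is meant among the compounds shown, and "the series" means these compounds.

Working notes on the series.

Compound 1 `N=C(N)Nc1cccc(C(=O)NNC(=O)CC(CC(=O)O)c2ccc(Br)cc2)c1` is the reference point. In a physicochemical assay for lipophilicity (a lower number here means a more polar compound, a higher number a more lipophilic compound), compound 1 gives 1.95. Compound 2 `COc1ccc(C(CC(=O)O)CC(=O)NNC(=O)c2cccc(NC(=N)N)c2)cc1` differs from it by one change (methoxy in place of bromo on an aromatic carbon), and in this assay compound 2 gives 1. Among the compounds with values here, the step of a number 0.95 log units lower from compound 1 to compound 2 (beyond the scatter) is the one measured instance of this change among the compounds at hand.

Compound 3 `CC(=N)Nc1cccc(C(=O)NNC(=O)CC(CC(=O)O)c2ccc(Br)cc2)c1` carries a different core, separated from compound 1 by methyl in place of amino on a carbon with a double bond to nitrogen. In this assay compound 3 gives 2.27, the highest of the three measured numbers; the step of a number 0.32 log units higher from compound 1 to compound 3 (beyond the scatter) lies beyond the scatter, as does its distance from compound 2.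

Compound 4 `COc1ccc(C(CC(=O)O)CC(=O)NNC(=O)c2cccc(NC(C)=N)c2)cc1` has not been measured. It differs from compound 3 by methoxy in place of bromo on an aromatic carbon, the same change that separates compound 2 from compound 1, at the same place; the change therefore occurs twice in all, once measured and once not. The cores of the two pairs differ only in the way already described between compound 1 and compound 3.

The expectation for compound 4 rests on a single precedent: the step is expected to be a number 0.95 log units lower from compound 3 to compound 4 (beyond the scatter), close to the earlier one, because compound 1 to compound 2 gave a number 0.95 log units lower from compound 1 to compound 2 (beyond the scatter) and nothing in the data suggests the other core would behave differently. Compound 4 is expected to give 1.32 in this assay, between 0.9 and 1.75.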

Compound 4, partition coefficient: 1.31
Estimate against measurement, compound 4: 0.01 log units above; measured number inside the range.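

In this assay the change from 4-bromophenyl to 4-methoxyphenyl gives a number 0.96 log units lower from compound 3 to compound 4 (beyond the scatter) and so closely matches a number 0.95 log units lower from compound 1 to compound 2 (beyond the scatter) in size, while methyl in place of amino gives a number 0.31 log units higher from compound 2 to compound 4 (beyond the scatter) and closely matches a number 0.32 log units higher from compound 1 to compound 3 (beyond the scatter) in the same way. The four compounds therefore form a closed square in which the two changes add up, and the methoxy-for-bromo step carries over from the core of compound 1 to the core of compound 3 with its size kept. Within the data shown here, this rests on only two instances of the change, at one place on the ring and in one assay, so it does not show that the step would transfer to any other core, and no measurement on hand bears on the reason for the agreement.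

Still open, as far as these compounds go, is whether a chloro group, a trifluoromethyl group or a longer ether chain such as ethoxy on the same aromatic carbon would fit the same additive picture. Also open, from the compounds shown here alone, is whether the step keeps its size when the carboxylic acid is replaced by a primary amide or when the guanidine is replaced by a simple amine.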